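The source may report more compounds than this note shows. Statements on the series, on what has been measured and on what is new or still open speak of the compounds shown alone.

Compound 1 `O=C1CSC(=O)N1C[C@H]1CN(c2ccc(-n3cc(-c4ccccn4)cn3)c(F)c2)C(=O)O1`: in an ADME assay on L02 cells (Homo sapiens) for cytotoxicity, read by MTT assay, with a stated time of 48 h (a higher number here means a weaker inhibitor, a lower number a stronger inhibitor), compound 1 gives > 400 ug/mL, which is a limit of the assay rather than a number.
Compound 2 `O=CNC[C@H]1CN(c2ccc(-n3cc(-c4ccccn4)cn3)c(F)c2)C(=O)O1`: in this assay compound 2 gives > 400 ug/mL, again a limit of the assay.

Compound 2 thus stands at the assay limit, as the limit of > 400 ug/mL in this assay, at which 2 of the 2 values shown sit, records. Compound 3 `CS(=O)(=O)NC[C@H]1CN(c2ccc(-n3cc(-c4ccccn4)cn3)c(F)c2)C(=O)O1` differs from compound 2 by methylsulfonyl in place of formyl on an amine nitrogen. Among the measured compounds shown here, the one measured step that bears on such a change, a step that the two limits leave unreadable from compound 1 to compound 2, cannot be read in size because both ends sit at the limit, so no measured step sets a direction here. The expected step that the limit leaves unreadable from compound 2 to compound 3 is therefore none beyond the scatter. Compound 3 is estimated at 500 ug/mL, with a range from 250 ug/mL to 1000 ug/mL, and most probably reported as a limit once more.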

Compound 3, half-maximal inhibitory concentration: > 400 ug/mL
Compound 3: a limit, no number (the forecaster's own chance of this, stated with the estimate: 85%); the middle value is on the limit's open side.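

No step among compound 1, compound 2 and compound 3 can be read, since all three sit at the same limit of the assay: the limit of > 400 ug/mL in this assay, at which 3 of the 3 values shown sit.

The compounds shown leave open how far beyond that limit each one lies, and whether any change on the shared core would give a readable number in this assay.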